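A Methyl on the Linking Carbon of Compound 3

This account rests on a few compounds, and the source may have more. Where it says the series, first, only, none or still open, it means among the compounds named here.

Compound 1 `CCCNC(=O)[C@H](CCC1CCCCC1)NC(=O)c1ccc(CNC(=O)c2cnn(-c3ccccc3)c2N)cc1` gives 5250 nM in an assay on HEK293T cells for inhibition of Discoidin domain-containing receptor 2 (Homo sapiens), read by NanoBRET, with a stated time of 2 h; on this read-out lower numbers stand for stronger inhibition and higher numbers for weaker inhibition.
Compound 2 `Nc1c(C(=O)NCc2ccc(C(=O)N[C@@H](CCC3CCCCC3)C(=O)NC3CCCN(C4COC4)C3)cc2)cnn1-c1ccccc1` gives 3720 nM.
Compound 3 `CS(=O)(=O)N1CCCC(NC(=O)[C@H](CCC2CCCCC2)NC(=O)c2ccc(CNC(=O)c3cc(-c4ccccc4)n[nH]3)cc2)C1` gives 21500 nM.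

Compound 3 stands with the highest number of the three, so it inhibits least strongly; its gap to compound 1 and to compound 2 lies beyond the scatter. Compound 4 `CC(NC(=O)c1cc(-c2ccccc2)n[nH]1)c1ccc(C(=O)N[C@@H](CCC2CCCCC2)C(=O)NC2CCCN(S(C)(=O)=O)C2)cc1` is compound 3 with one change: methyl in place of hydrogen on a saturated chain carbon bound to an amide-type nitrogen and an aromatic carbon. For the measured compounds named here, only one measured step exists, a 1.4-fold lower number from compound 1 to compound 2 (0.15 log units; within the scatter), and it alters a different part of the molecule, so it offers no guidance for this change. With nothing comparable measured, the expectation is no step beyond the scatter, and the step from compound 3 to compound 4 is estimated as a 1.1-fold lower number from compound 3 to compound 4 (0.03 log units; within the scatter). Compound 4 is therefore expected to give about 20000 nM, within a range of 7000 nM to 60000 nM.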

Compound 4, half-maximal inhibitory concentration: 27700 nM
The estimate for compound 4 lay 1.4-fold (0.14 log units) below the measured number, within the range that was stated.
By their numbers in this assay, from the lowest: compounds 2 and 1 (each within the scatter of the next); then compounds 3 and 4 (each within the scatter of the next).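

In this assay methyl in place of hydrogen on a saturated chain carbon bound to an amide-type nitrogen and an aromatic carbon gives a 1.3-fold higher number from compound 3 to compound 4 (0.11 log units; within the scatter) and this is the only reading at this carbon among the compounds shown. On this read-out, the added methyl cannot be told apart from the hydrogen it replaces. Nothing measured here explains the result.

Going by these compounds, whether a longer chain such as ethyl, or an amine, would read the same at this carbon stays open. So does whether methyl would read the same on the core of compound 1.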